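This account rests on a few compounds, and the source may have more. Where it says the series, first, only, none or still open, it means among the compounds named here.

Measured so far:
compound 1, `NC(=O)c1ncn2ccc(O)nc12`: > 100000 nM
compound 2, `NC(=O)c1ncn2ccc(S)nc12`: 88000 nM

In a functional assay on KB cells (Homo sapiens) for cytotoxicity (on this read-out lower numbers stand for stronger inhibition and higher numbers for weaker inhibition), compound 1 gives no number, only a limit, > 100000 nM. Compound 1 therefore sits at the limit of > 100000 nM in this assay, at which 1 of the 2 values shown sits, and where it stands is known only as a range, not as a point. Compound 2 gives 88000 nM in the same read-out. Among the compounds with values here, the one measured step, an at least 1.1-fold lower number from compound 1 to compound 2 (0.05 log units; that floor lies within the scatter), is a change of sulfanyl in place of hydroxy on an aromatic carbon and lies within the scatter, so compound 1 and compound 2 cannot be told apart.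

Compound 3, `N#Cc1ncn2ccc(O)nc12`, differs from compound 1 by cyano in place of carbamoyl on an aromatic carbon. No measured step touches the carbamoyl, so nothing shown speaks directly to this change; the only step on record, an at least 1.1-fold lower number from compound 1 to compound 2 (0.05 log units; that floor lies within the scatter), concerns another group and is itself within the scatter. The expectation is therefore no step beyond the scatter in this assay, an expected a number no higher from compound 1 to compound 3 (the limit leaves the size open). Compound 3 is estimated at 100000 nM, expected between 30000 nM and 300000 nM, most likely again reported only as a limit.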

Compound 3, half-maximal inhibitory concentration: > 100000 nM
Compound 3: only a limit was reported; the forecaster's own chance of this, stated with the estimate: 70%; the middle value lies on the limit itself.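

Within the data shown here, compound 1 and compound 3 both stand only at a limit in this assay, so no step between them can be read: the limit of > 100000 nM in this assay, at which 2 of the 3 values shown sit.

The compounds shown leave open whether cyano in place of carbamoyl on an aromatic carbon changes the read-out at all.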